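Extending the Methoxy Chain on the Sulfonamide Nitrogen Aryl

A few compounds are considered here, and "the series" means these few. Any claim that something is new, unique, unknown or untested is made for them only; others in the source may bear on it.

Compound 1, `COc1ccc(NS(=O)(=O)c2ccc(N3CCNC3=O)cc2)cc1`: > 1000 nM
Compound 2, `O=C1NCCN1c1ccc(S(=O)(=O)Nc2ccc(F)c(F)c2)cc1`: 620 nM
Compound 3, `O=C1NCCN1c1ccc(S(=O)(=O)Nc2cccc(Oc3ccccc3)c2)cc1`: 220 nM

In a functional assay on MCF7 cells (Homo sapiens) for antiproliferative activity, read by sulforhodamine B assay, with a stated time of 48 h (a higher number here means a weaker inhibitor, a lower number a stronger inhibitor), compound 1 reaches only a limit of the assay, > 1000 nM, so its position among the three measured compounds is known just as a bound. Compound 2 gives 620 nM in this assay, and compound 3 gives 220 nM. Among the measured compounds shown here, the one step measured in a single place is an at least 1.6-fold lower number from compound 1 to compound 2 (0.20 log units; that floor lies within the scatter), and its floor lies within the scatter, a consequence of the limit of > 1000 nM in this assay, at which 1 of the 3 values shown sits.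

The unmeasured compound 4, `CCCCCCOc1ccc(NS(=O)(=O)c2ccc(N3CCNC3=O)cc2)cc1`, differs from compound 1 at a different place: pentyl in place of hydrogen on a saturated chain carbon bound to an oxygen on an aromatic ring. For the measured compounds named here, no measured step changes the chain on the oxygen of the aromatic ring, so the step from compound 1 to compound 2 bears on compound 4 only by showing that the shared core can reach a numbered value once the group on the sulfonamide nitrogen is altered. Going by the values given here, with no direct precedent, a step beyond the scatter in this assay is expected in neither direction with confidence, and the estimate stays wide.

Compound 4 is therefore expected to give about 800 nM in this assay, within a range from 200 nM to 3000 nM. That estimate corresponds to an at least 1.2-fold lower number from compound 1 to compound 4 (0.09 log units; that floor lies within the scatter).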

Compound 4, half-maximal inhibitory concentration: > 1000 nM
Compound 4 gave a limit, no number; the forecaster's own chance of this, stated with the estimate: 35%; middle value at least 1.2-fold (0.09 log units) away from the limit.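

In this assay compound 4 gives only a limit, > 1000 nM. No step between compound 1 and compound 4 can be read, because both values are limits: the limit of > 1000 nM in this assay, at which 2 of the 4 values shown sit.

The compounds shown leave open whether hexyloxy in place of methoxy changes the number at all, in either direction.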